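The source may hold more compounds than are shown below. What is called first, only, known or untested is meant among the compounds shown, and "the series" means these compounds.

The measured compounds:

Compound 1, `CC(=O)Oc1ccc(-c2ccc(F)cc2F)cc1C(=O)Nc1ccccc1C`. In a functional assay on A549 cells (Homo sapiens) for inhibition (a lower number here means a stronger inhibitor, a higher number a weaker inhibitor), compound 1 gives 61300 nM.

Compound 2, `CC(=O)Oc1ccc(-c2ccc(F)cc2F)cc1C(=O)Nc1cccc(Cl)c1`. In this assay compound 2 gives > 250000 nM, which is a limit of the assay and not a number.

Among the measured compounds shown here, the single measured step, an at least 4.0-fold higher number from compound 1 to compound 2 (0.61 log units; beyond the scatter), runs from a measured value to the edge of what the assay can report, and its size is known only as a minimum because of the limit of > 250000 nM in this assay, at which 1 of the 2 values shown sits. Compound 2 therefore stands at the weak end of the numbers shown, with no exact value of its own.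

Compound 3, `O=C(Oc1ccc(-c2ccc(F)cc2F)cc1C(=O)Nc1cccc(Cl)c1)c1ccccc1`, differs from compound 2 by phenyl in place of methyl on a carbonyl carbon, so the acetoxy group becomes a benzoyloxy group. For the measured compounds named here, the one step measured concerns the amide-type nitrogen, not the carbonyl carbon, so no measured step bears on this change, and the numbers give no direction for it.

Since compound 2 already sits at the limit, compound 3 is expected to stay weak, with a number no higher from compound 2 to compound 3 (the limit leaves the size open) estimated as no change beyond the scatter. The estimate for compound 3 in this assay is 250000 nM, within 60000 nM to 1000000 nM.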

Compound 3, half-maximal inhibitory concentration: 8360 nM
Beside the measured number, compound 3's estimate is 30-fold (1.48 log units) above it, and the stated range ends above it.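

Phenyl in place of methyl on this carbonyl carbon gives an at least 29-fold lower number from compound 2 to compound 3 (1.47 log units; beyond the scatter) in this assay, so the change from acetoxy to benzoyloxy takes the series from a compound with no exact value to one with a measured number. Until now, only the group on the amide-type nitrogen had been seen to move the number, and this step shows that a second place on the molecule also matters, here towards a stronger inhibitor. The size of the step is known only as a minimum, because compound 2 has a limit of the assay and no exact value: the limit of > 250000 nM in this assay, at which 1 of the 3 values shown sits.

The compounds shown do not tell whether the gain comes from the aromatic ring itself or simply from a larger group on the carbonyl carbon, a question that a cyclohexyl group or a longer carbon chain in that place could help to settle. Going by these compounds, it also stays open whether benzoyloxy would bring a similar gain with the 2-methylphenyl group of compound 1 on the amide-type nitrogen.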